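Amide substituent series against the F508del CFTR binding readout

A few compounds are considered here, and "the series" means these few. Any claim that something is new, unique, unknown or untested is made for them only; others in the source may bear on it.

Measured so far:
compound 1 `COc1ccc(Cl)cc1Nc1nc2c(s1)CCCCc1nc(NC(=O)C(C)(C)C)sc1-2`, 4100 nM
compound 2 `COc1ccc(Cl)cc1Nc1nc2c(s1)CCCCc1nc(NC(=O)C(C)C)sc1-2`, 8700 nM

In an assay on cells (Epithelial cell) with Cystic fibrosis transmembrane conductance regulator variant F508del (Homo sapiens) as the target, read by fluorescence, with a stated time of 20 h (a higher number here means a weaker inhibitor, a lower number a stronger inhibitor), compound 2 gives the highest of the two numbers; its nearest neighbour is compound 1, with a 2.1-fold higher number from compound 1 to compound 2 (0.33 log units; beyond the scatter) separating them. Compound 3 `CCC(C)C(=O)Nc1nc2c(s1)-c1nc(Nc3cc(Cl)ccc3OC)sc1CCCC2` differs from compound 2 by methyl in place of hydrogen on a saturated chain carbon, two bonds along the chain from a carbonyl carbon, so the change is methyl to ethyl, isopropyl to sec-butyl. Among the compounds with values here, the only step measured so far concerns an added methyl on the carbon bound to the carbonyl, where the gain from the extra carbon was modest; a methyl placed one bond further out has no direct precedent. A comparable, modest gain in this assay is expected, a 1.6-fold lower number from compound 2 to compound 3 (0.20 log units; within the scatter). Compound 3 is therefore estimated at 5500 nM, within 2500 nM to 12000 nM.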

Compound 3, half-maximal inhibitory concentration: 2900 nM
For compound 3 the middle estimate is 1.9-fold (0.28 log units) above the measured one; measured number inside the range.
By their numbers in this assay, from the lowest: compounds 3 and 1 (each within the scatter of the next); then compound 2.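

In this assay, methyl in place of hydrogen on a saturated chain carbon, two bonds along the chain from a carbonyl carbon, lowers the number (a 3.0-fold lower number from compound 2 to compound 3 (0.48 log units; beyond the scatter)), so the added carbon need not sit on the carbon bound to the carbonyl. Sec-butyl in place of tert-butyl on a carbonyl carbon leaves the two amides unresolved (a 1.4-fold lower number from compound 1 to compound 3 (0.15 log units; within the scatter)). No evidence here accounts for either step. On these data alone, whether a longer chain such as n-pentyl or a ring such as cyclohexyl would lower the number further stays open.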